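A few compounds are considered here, and "the series" means these few. Any claim that something is new, unique, unknown or untested is made for them only; others in the source may bear on it.

Measured so far in an ADME assay on the whole organism (plasma) for pharmacokinetics, with Rattus norvegicus as the target, with a stated time of 6 h, at a dose of 10 mg/kg by the oral route; a higher number here means more compound in the circulation at the dose given, a lower number less compound in the circulation:
- compound 1, `Cc1nc(N[C@H](C)C2CC2)nc(N[C@@H]2C[C@H](C(C)(C)O)[C@@H](O)[C@H]2O)c1-c1nc2cnccc2s1`: 5330 ng.h/mL
- compound 2, `COCCNc1nc(C)c(-c2nc3cnccc3s2)c(N[C@@H]2C[C@H](C(C)(C)O)[C@@H](O)[C@H]2O)n1`: 617 ng.h/mL
- compound 3, `CCC(O)(CC)[C@H]1C[C@@H](Nc2nc(NCC3CC3)nc(C)c2-c2nc3c(C)nccc3s2)[C@H](O)[C@@H]1O`: 5130 ng.h/mL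

Compound 3 stands second highest of the three; its number and that of compound 1 lie within the scatter of each other, so no order between them can be read, while compound 2 lies well below both.

The next compound, compound 4, `CCC(O)(CC)[C@H]1C[C@@H](Nc2nc(NCCOC)nc(C)c2-c2nc3c(C)nccc3s2)[C@H](O)[C@@H]1O`, differs from compound 3 in one place: methoxymethyl in place of cyclopropyl on a saturated chain carbon bound to a nitrogen on an aromatic ring. Within the data shown here, one measured step bears on this change. It is an 8.6-fold lower number from compound 1 to compound 2 (0.94 log units; beyond the scatter), where a cyclopropyl-bearing chain on the ring nitrogen was likewise replaced by the methoxyethyl chain; the two substituents swapped there are not identical to those swapped here, since the chain on compound 1 carries one more carbon than the chain on compound 3, so the step is a neighbour rather than a repeat.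

Among the measured compounds shown here, on that basis a drop is expected for compound 4 in this assay, of a size near the step seen, a 5.7-fold lower number from compound 3 to compound 4 (0.76 log units; beyond the scatter), though the single comparison leaves the size uncertain. The estimate for compound 4 is 900 ng.h/mL, with a range of 350 ng.h/mL to 2500 ng.h/mL.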

Compound 4, area under the concentration-time curve: 723 ng.h/mL
Beside the measured number, compound 4's estimate is 1.2-fold (0.10 log units) above it, and the stated range covers the measured number.
By their numbers in this assay, from the lowest: compounds 2 and 4 (each within the scatter of the next); then compounds 3 and 1 (each within the scatter of the next).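

In this assay, the change from cyclopropylmethyl to 2-methoxyethyl on a nitrogen on an aromatic ring gives a 7.1-fold lower number from compound 3 to compound 4 (0.85 log units; beyond the scatter). Together with an 8.6-fold lower number from compound 1 to compound 2 (0.94 log units; beyond the scatter), this makes two pairs with a fall beyond the scatter on moving to 2-methoxyethyl, so the fall is not confined to one background: compound 3 and compound 4 share a different remainder of the molecule from compound 1 and compound 2. Within the pair from compound 3, the change removes the three-membered ring and brings in an oxygen in a single swap, so the two contributions cannot be separated.

Nothing available explains the lower exposure. Going by these compounds, whether the ring or the ether oxygen governs the number remains open, and a straight butyl chain or a chain ending in an amine at this nitrogen would bear on that.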